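The compounds below may be only part of what the source reports. "The series", "measured", "known", "first", "only" and "open" are said of these compounds alone.

Measured so far in a functional assay on HEK293 cells for agonist activity at D(4) dopamine receptor (Homo sapiens), read by FLIPR; on this read-out higher numbers stand for an effect only at larger amounts of compound and lower numbers for an effect already at smaller amounts:
compound 1 `COc1ccccc1C1CCN(CC(=O)Nc2cccc(C)c2)CC1` — 420 nM
compound 2 `Cc1cccc(NC(=O)CN2CCC(c3ccc(O)cn3)CC2)c1` — 3.8 nM
compound 3 `Cc1cccc(NC(=O)CN2CCC(c3cccc(C#N)n3)CC2)c1` — 36 nM

Compound 3 holds the second highest of the three numbers in this assay: compound 2 sits a 9.5-fold higher number from compound 2 to compound 3 (0.98 log units; beyond the scatter) apart, compound 1 a 12-fold lower number from compound 1 to compound 3 (1.07 log units; beyond the scatter) apart.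

Compound 4 `Cc1cccc(NC(=O)CN2CCC(c3ccccc3F)CC2)c1` differs from compound 3 by 2-fluorophenyl in place of 6-cyanopyridin-2-yl on a saturated ring carbon. The step from a 2-methoxyphenyl to the 6-cyanopyridin-2-yl of compound 3 was a 12-fold lower number from compound 1 to compound 3 (1.07 log units; beyond the scatter), and to the 5-hydroxypyridin-2-yl of compound 2 it was a 110-fold lower number from compound 1 to compound 2 (2.04 log units; beyond the scatter). Going by the values given here, compound 4 returns to a ring of carbon only, though with fluorine rather than methoxy; no measured pair tests that exchange directly. On balance a number between those of compound 3 and compound 1 is expected, so compound 4 is expected to show a 4.2-fold higher number from compound 3 to compound 4 (0.62 log units; beyond the scatter) in this assay.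

Estimated for compound 4: 150 nM, range 40 nM to 600 nM.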

Compound 4, half-maximal effective concentration: 1 nM
Compound 4: the middle estimate sits 150-fold (2.18 log units) above what was measured; the whole stated range lies above it.
By their numbers in this assay, from the lowest: compound 4; then compound 2; then compound 3; then compound 1.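

With fluoro in place of methoxy on an aromatic carbon, this assay shows a 420-fold lower number from compound 1 to compound 4 (2.62 log units; beyond the scatter), so a ring of carbon only at this saturated ring carbon does not by itself set the high number of compound 1. The 2-fluorophenyl also passes both pyridine groups, with a 36-fold lower number from compound 3 to compound 4 (1.56 log units; beyond the scatter) and a 3.8-fold lower number from compound 2 to compound 4 (0.58 log units; beyond the scatter), so a ring hetero atom is not needed for a low number here. Nothing available explains these steps.

On these data alone, how a phenyl bearing chloro or trifluoromethyl in place of fluoro would read stays open. Also open, as far as these compounds go, is whether fluoro on a pyridine ring would give a similar number.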